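A few compounds are considered here, and "the series" means these few. Any claim that something is new, unique, unknown or untested is made for them only; others in the source may bear on it.

Measured compounds:
- Compound 1, `Cc1cn([C@@H]2O[C@H](CO[Si](C)(C)C(C)(C)C(C)C)[C@@]3(OS(=O)(=O)C=C3NC(=O)NC(=O)c3ccccc3)[C@H]2O[Si](C)(C)C(C)(C)C)c(=O)n(C)c1=O`: in an ADME assay on HEL cells (Homo sapiens) for cytotoxicity, with a stated time of 3 days (a lower number here means that less compound is tolerated, a higher number that more compound is tolerated), compound 1 gives > 50000 nM, which is a limit of the assay.
- Compound 2, `Cc1cn([C@@H]2O[C@H](COC(=O)c3ccccc3)[C@@]3(OS(=O)(=O)C=C3NC(=O)NC(=O)c3ccccc3)[C@H]2O)c(=O)n(C)c1=O`: in this assay compound 2 gives > 100000 nM, which is also a limit of the assay.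

Compound 2 therefore stands only at a limit, and no number is known for it; the other value shown is a limit as well, as the limit of > 100000 nM in this assay, at which 1 of the 2 values shown sits, and the limit of > 50000 nM in this assay, at which 1 of the 2 values shown sits, make plain. Compound 3, `Cc1cn([C@@H]2O[C@H](COC(=O)c3ccccc3)[C@@]3(OS(=O)(=O)C=C3NC(=O)NC(=O)c3ccccc3)[C@H]2O[Si](C)(C)C(C)(C)C)c(=O)n(C)c1=O`, differs from compound 2 by a group of 7 heavy atoms (6 carbon, 1 silicon; no ring) in place of a hydrogen atom, on an oxygen on a saturated carbon. No measured step connects two of these compounds. With both measured compounds at limits, the step from compound 2 to compound 3 is expected to be a number no higher from compound 2 to compound 3 (the limit leaves the size open), none beyond the scatter. In this assay compound 3 is expected at 100000 nM, within a range from 40000 nM to 250000 nM.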

Compound 3, half-maximal cytotoxic concentration: 100000 nM
Estimate against measurement, compound 3: no gap at the digits printed; low and high end bracket the measured number.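

In this assay, for the compounds shown here, compound 3 gives 100000 nM, the only actual number among the three compounds, so the group of 7 heavy atoms (6 carbon, 1 silicon; no ring) on this oxygen on a saturated carbon is tied to a stated concentration rather than a limit. The change in place of a hydrogen atom reads as a number no higher from compound 2 to compound 3 (the limit leaves the size open), and neither this step nor the step involving compound 1 can be read in size, as each starts from a limit of the assay. Nothing given here bears on a cause for the value.

What the compounds shown leave open is how the read-out responds with an acetyl group or a longer alkyl chain on this oxygen. Going by these compounds, it also remains open whether an amine at this place would give a value clearly lower than that of compound 3.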